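The compounds below may be only part of what the source reports. "The series", "measured", "known", "first", "only" and "open" are said of these compounds alone.

Among the measured compounds shown here, compound 2 `CCn1cc(-c2nc3ccccc3s2)c(=O)c2cc(F)c(N3CCNCC3)cc21` gives 11300 nM in a functional assay on A2780 cells (Homo sapiens) for cytotoxicity, read by MTT assay, with a stated time of 48 h (on this read-out lower numbers stand for stronger inhibition and higher numbers for weaker inhibition), the higher of the two numbers measured so far; its nearest neighbour, compound 1 `CCn1cc(-c2nc3ccccc3[nH]2)c(=O)c2cc(F)c(N3CCNCC3)cc21`, gives 800 nM. For the measured compounds named here, the single measured step, a 14-fold higher number from compound 1 to compound 2 (1.15 log units; beyond the scatter), is the only one that bears on the next change. Compound 3 `CCn1cc(-c2nc3ccc(Cl)cc3[nH]2)c(=O)c2cc(F)c(N3CCNCC3)cc21` differs from compound 2 by 6-chloro-1H-benzimidazol-2-yl in place of 1,3-benzothiazol-2-yl on an aromatic carbon. Going by the values given here, this largely reverses the step from compound 1 to compound 2, so a drop of comparable size is expected, a 13-fold lower number from compound 2 to compound 3 (1.10 log units; beyond the scatter); the added chlorine has no precedent in this set. Compound 3 is therefore estimated at 900 nM, within 300 nM to 3000 nM.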

Compound 3, half-maximal inhibitory concentration: 4900 nM
The estimate for compound 3 lay 5.4-fold (0.74 log units) below the measured number; the whole stated range lies below it.
By their numbers in this assay, from the lowest: compound 1; then compound 3; then compound 2.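

In this assay, chloro in place of hydrogen on the 1H-benzimidazol-2-yl group gives a 6.1-fold higher number from compound 1 to compound 3 (0.79 log units; beyond the scatter), so this substituent is not neutral here. Set against 1,3-benzothiazol-2-yl, the 6-chloro-1H-benzimidazol-2-yl group gives only a 2.3-fold lower number from compound 2 to compound 3 (0.36 log units; beyond the scatter), so just part of the advantage of compound 1 over compound 2 remains once the chlorine is present. Nothing available explains either step. Open, on these data alone, is whether the loss is particular to chloro: a fluoro or a methoxy group in the same place would test that. Also open, as far as these compounds go, is how a chlorine on the 1,3-benzothiazol-2-yl group would behave.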